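The compounds below may be only part of what the source reports. "The series", "measured", "known", "first", "only" and "open" are said of these compounds alone.

Working notes on the series. Of the compounds shown here, two carry the shared core and have been measured in a functional assay for antagonist activity at transient receptor potential cation channel subfamily V member 1 (Homo sapiens); on this read-out higher numbers stand for weaker inhibition and lower numbers for stronger inhibition. Compound 1 `O=C(O)COCc1nc(Nc2ccc(C(F)(F)F)cc2)c2ccc(-c3ncccc3C(F)(F)F)cc2n1` gives 81 nM in this assay. Compound 2 `CS(=O)(=O)CCc1nc(Nc2ccc(C(F)(F)F)cc2)c2ccc(-c3ncccc3C(F)(F)F)cc2n1` gives 36 nM in this assay and stands at the lowest of the two numbers, with compound 1 the nearest, a modest step apart. Among the compounds with values here, the single measured step at this position is a 2.3-fold lower number from compound 1 to compound 2 (0.35 log units; beyond the scatter), a modest shift from an acid-bearing chain to a sulfone-bearing one.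

Compound 3 `FC(F)(F)c1ccc(Nc2nc(CN3CCCC3)nc3cc(-c4ncccc4C(F)(F)F)ccc23)cc1` has not yet been measured. It differs from compound 2 by pyrrolidin-1-yl in place of (methylsulfonyl)methyl on a saturated chain carbon bound to an aromatic carbon. The measured step bears on it only in so far as it shows that exchanging the group on this saturated chain carbon moved the number modestly; neither side of that step matches the entering pyrrolidin-1-yl, so direction cannot be read from it. A step of about the same size is therefore expected, with no clear direction, so that the estimated change a 1.4-fold higher number from compound 2 to compound 3 (0.14 log units; within the scatter) lies near the scatter. For compound 3 the estimate in this assay is 50 nM, within 15 nM to 170 nM.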

Compound 3, half-maximal inhibitory concentration: 25 nM
Compound 3: the middle estimate sits 2.0-fold (0.30 log units) above what was measured, within the range that was stated.
By their numbers in this assay, from the lowest: compounds 3 and 2 (each within the scatter of the next); then compound 1.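

In this assay, pyrrolidin-1-yl on the saturated chain carbon bound to an aromatic carbon gives a 1.4-fold lower number from compound 2 to compound 3 (0.16 log units; within the scatter). This position therefore accepts two quite different groups without a distinguishable change in the number: one carrying a sulfone and no ring, the other a five-membered non-aromatic ring with a single nitrogen and no double bonds outside aromatic rings. Against carboxymethoxy, the same exchange gives a 3.2-fold lower number from compound 1 to compound 3 (0.51 log units; beyond the scatter), so carboxymethoxy now stands apart from both other groups, with the steps to each of them beyond the scatter, and no measurement shown here explains why these groups read as they do.

The compounds shown leave open whether the ring of pyrrolidin-1-yl matters at all, a question that an open-chain dimethylamino or a six-membered morpholin-4-yl on the same carbon would put to the test. They also leave open whether the separate standing of compound 1 goes with its carboxylic acid or with the ether oxygen in its chain, which a methyl ester or a plain propanoic acid chain at this position would help to separate.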